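Bromo to methoxy on the indole ring of two diterpenoid-indole cores

This account rests on a few compounds, and the source may have more. Where it says the series, first, only, none or still open, it means among the compounds named here.

Compound 1 `COC(=O)[C@@]1(C)CCC=C2[C@@H]1CC[C@@H](C)[C@]2(C)Cc1c(C)[nH]c2ccc(Br)cc12` and compound 2 `COC(=O)[C@@]1(C)CCC=C2[C@@H]1CC[C@@H](C)[C@]2(C)Cc1c(C)[nH]c2ccc(OC)cc12` share one core; compound 3 `COC(=O)[C@@]1(C)CC[C@@H]2C3=C1CC[C@@H](C)[C@]3(C)Cc1c2[nH]c2ccc(Br)cc12` and compound 4 `COC(=O)[C@@]1(C)CC[C@@H]2C3=C1CC[C@@H](C)[C@]3(C)Cc1c2[nH]c2ccc(OC)cc12` share another, whose difference from the core of compound 1 is not broken down here. In a functional assay on A549 cells (Homo sapiens) for inhibition, read by sulforhodamine B assay, with a stated time of 48 h (on this read-out higher numbers stand for weaker inhibition of growth and lower numbers for stronger inhibition of growth), compound 1 gives 15000 nM, and compound 2 gives 16000 nM. The change between them is methoxy in place of bromo on an aromatic carbon, and the step it made was a 1.1-fold higher number from compound 1 to compound 2 (0.03 log units; within the scatter). In this assay compound 3 gives 17000 nM; its number sits within the scatter of both compound 1 and compound 2, so none of the three measured compounds can be set apart from the others.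

Compound 4 carries the same kind of change on its own core: methoxy in place of bromo on an aromatic carbon. The places are not identical, since the aromatic carbon of compound 1 lies in a fused or bridged system of two rings while that of compound 3 lies in a fused or bridged system of five rings, so the change is of the same kind rather than the same.

The expected step is a 1.1-fold higher number from compound 3 to compound 4 (0.02 log units; within the scatter), set beside the same kind of change, because a 1.1-fold higher number from compound 1 to compound 2 (0.03 log units; within the scatter) in this assay stayed within the scatter. On this basis compound 4 is expected to give about 18000 nM in this assay, with a range estimated from 9000 nM to 36000 nM.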

Compound 4, concentration for 50% growth inhibition: 7700 nM
Compound 4: middle estimate off by 2.3-fold (0.37 log units), on the high side; measured number below the stated range.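

In this assay, methoxy in place of bromo on an aromatic carbon of the core of compound 3 gives a 2.2-fold lower number from compound 3 to compound 4 (0.34 log units; beyond the scatter), a modest step and the only one in this series that lies beyond the scatter. Set beside the earlier step on the core of compound 1, this step cannot be told apart from it, since the gap between the two stays within what two such steps can scatter: the same change on two cores in this assay, a 1.1-fold higher number (0.03 log units; within the scatter) from compound 1 to compound 2 and a 2.2-fold lower number (0.34 log units; beyond the scatter) from compound 3 to compound 4, 2.4-fold (0.37 log units) apart, within the scatter of two such steps The pair therefore gives no firm sign that the change behaves differently on the two cores, but it does not establish that the change carries over unaltered either, as each core contributes only one bromo and methoxy pair and the step beyond the scatter is seen on the core of compound 3 alone.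

Still open, on these data alone, is whether the lower number on the core of compound 3 is particular to methoxy, or whether a hydroxyl, an amine or a longer chain such as ethoxy on the same aromatic carbon would give a similar step on either core. Also open, as far as these compounds go, is whether the step would hold with a carboxylic acid or an amide in place of the methyl ester.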